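This account rests on a few compounds, and the source may have more. Where it says the series, first, only, none or still open, it means among the compounds named here.

Measured compounds:
- Compound 1 `OC[C@H]1OC(n2cnc3c(SCc4ccccc4)nccc32)[C@H](O)[C@@H]1O` gives 30% in a functional assay on EL4 cells (Mus musculus) for inhibition, tested at 100 uM; a lower number here means less inhibition, a higher number more inhibition at the concentration tested (going by the name of the read-out).
- Compound 2 `c1ccc(Nc2[nH]ccc3ncnc2-3)cc1` gives 26%.
- Compound 3 `OCCNc1[nH]ccc2ncnc1-2` gives < 5%, which is a limit of the assay and not a number.

Among the measured compounds shown here, only two numbers are available in this assay. Compound 1 gives the larger of them, but compound 2 sits within the usual scatter of it, so no ordering of the two is claimed. The third entry, compound 3, is covered by the limit of < 5% in this assay, at which 1 of the 3 values shown sits, and adds no number. No pair among the measured compounds differs in one place, so no measured step is at hand, and nothing here points to a cause for any of the three values.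

The next compound, compound 4 `CCNc1nccc2c1ncn2C1O[C@H](CO)[C@@H](O)[C@H]1O`, keeps the sugar and the core of compound 1 and changes one group: ethylamino in place of benzylsulfanyl on an aromatic carbon. With only the values of compound 1 and compound 2 to lean on, and compound 3 at the limit, the step from compound 1 to compound 4 is expected to lower inhibition, by an amount beyond the scatter, though a result within the scatter cannot be excluded. The step is estimated as a number 18 percentage points lower from compound 1 to compound 4 (beyond the scatter). For compound 4 the expected value in this assay is 12%, between 2% and 28%, with a real chance that only a limit is reported.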

Compound 4, a percentage reported as inhibition, at one concentration (the size of the read-out at that concentration, not a potency): 8%
For compound 4 the middle estimate is 4 percentage points above the measured one, within the range that was stated.
By their numbers in this assay, from the lowest: compound 4; then compounds 2 and 1 (each within the scatter of the next). At a limit, below all of these: compound 3.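

Among the compounds shown here, this is the first measured step: on the aromatic carbon next to the ring nitrogen, with the sugar and the core of compound 1 kept, ethylamino in place of benzylsulfanyl gives in this assay a number 22 percentage points lower from compound 1 to compound 4 (beyond the scatter). For the compounds shown here, the group at this position therefore bears on inhibition at the concentration tested, which the earlier compounds could not show, as no two of them differ in one place. Little of the read-out remains for reading further changes downward from compound 4, and compound 3 is held at a limit of the assay and not a number: the limit of < 5% in this assay, at which 1 of the 4 values shown sits.

From the compounds shown here alone, the step exchanges the sulfur, the six-membered aromatic ring and the chain together, so it remains open which of them goes with the change; benzylamino and ethylsulfanyl at this position would separate them. Also open, going by these compounds, are how a longer alkylamino chain or a carboxylic acid would read at this position, and whether the step holds on the core without the sugar, while a single tested concentration gives no potency.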